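Changing the carbonyl substituent: compound 3 to compound 4

The source may hold more compounds than are shown below. What is called first, only, known or untested is meant among the compounds shown, and "the series" means these compounds.

Values in an ADME assay on HepG2 2.2.15 cells (Homo sapiens) for cytotoxicity; a higher number here means that more compound is tolerated, a lower number that less compound is tolerated:
- compound 1 `CC(=O)OCCc1c(-c2ccccc2Cl)c2cc(Cl)ccc2[nH]c1=O`: 27000 nM
- compound 2 `CCCCCCCC(=O)OCCc1c(-c2ccccc2Cl)c2cc(Cl)ccc2[nH]c1=O`: 78000 nM
- compound 3 `COCC(=O)OCCc1c(-c2ccccc2Cl)c2cc(Cl)ccc2[nH]c1=O`: 74000 nM

Compound 3 and compound 2 sit together at the high end of these numbers, the gap being a 1.1-fold lower number from compound 2 to compound 3 (0.02 log units; within the scatter). Compound 1 lies lower, with a 2.7-fold higher number from compound 1 to compound 3 (0.44 log units; beyond the scatter).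

The next compound, compound 4 `O=C(OCCc1c(-c2ccccc2Cl)c2cc(Cl)ccc2[nH]c1=O)C1CCCC1`, carries this difference: cyclopentyl in place of methoxymethyl on a carbonyl carbon. Going by the values given here, no measured step makes this exact exchange of cyclopentyl for methoxymethyl on a carbonyl carbon, so the evidence is indirect. Two modest steps lead away from compound 1, namely a 2.9-fold higher number from compound 1 to compound 2 (0.46 log units; beyond the scatter) and a 2.7-fold higher number from compound 1 to compound 3 (0.44 log units; beyond the scatter). Both replace hydrogen, which is not what happens here. The closer parallel swaps one substituent for a quite different one, and it gave only a 1.1-fold lower number from compound 2 to compound 3 (0.02 log units; within the scatter). With just three values, that single comparison is thin support. Even so, no step beyond the scatter is expected in this assay, and no direction is favoured with any confidence. The expected move is a 1.1-fold lower number from compound 3 to compound 4 (0.02 log units; within the scatter). The estimate for compound 4 is 70000 nM, with an expected range from 35000 nM to 130000 nM.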

Compound 4, half-maximal cytotoxic concentration: 46000 nM
Compound 4: the middle estimate sits 1.5-fold (0.18 log units) above what was measured; the measured number falls inside the stated range.
By their numbers in this assay, from the lowest: compounds 1, 4, 3 and 2 (each within the scatter of the next, the first and the last beyond it).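

Cyclopentyl on the carbonyl carbon brings the first ring at this position, and in this assay it stays within the scatter of all three earlier compounds (a 1.6-fold lower number from compound 3 to compound 4 (0.21 log units; within the scatter); a 1.7-fold lower number from compound 2 to compound 4 (0.23 log units; within the scatter); a 1.7-fold higher number from compound 1 to compound 4 (0.23 log units; within the scatter)). Compound 4 therefore belongs to neither end of the series: methyl in compound 1 lies beyond the scatter of heptyl in compound 2 and of methoxymethyl in compound 3, yet cyclopentyl cannot be separated from any of these three groups, so the earlier split into a low and a high group no longer holds as two clear classes, and a ring of carbon only at this place gives no step beyond the scatter. No measurement available here accounts for where compound 4 falls, or for any of these numbers.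

Still open, as far as these compounds go, is whether a charged group at this place, such as an amine or a carboxylic acid, would give a step beyond the scatter from compound 4. Also open, from the compounds shown here alone, is how an aromatic ring such as phenyl, or a six-membered carbon ring such as cyclohexyl, would read against cyclopentyl in this assay.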